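Swapping the aryl ketone partner on a trimethoxyphenyl pyrazole

A few compounds are considered here, and "the series" means these few. Any claim that something is new, unique, unknown or untested is made for them only; others in the source may bear on it.

Measured compounds:
compound 1, `COc1cc(-c2cc(/C=C/C(=O)c3ccc(Cl)c(Cl)c3)[nH]n2)cc(OC)c1OC`, 67%
compound 2, `COc1ccc(C(=O)/C=C/c2cc(-c3cc(OC)c(OC)c(OC)c3)n[nH]2)cc1`, 75%

In a functional assay on NCI-H522 cells (Homo sapiens) for cytotoxicity, read by sulforhodamine B assay, with a stated time of 48 h, tested at 1 uM (on this read-out lower numbers stand for a stronger effect and higher numbers for a weaker effect at the one concentration tested), compound 2 gives 75%. Among the compounds with values here, its only neighbour is compound 1, and the two sit within the scatter of each other: a number 8 percentage points higher from compound 1 to compound 2 (within the scatter). Compound 3, `COc1cc(-c2cc(/C=C/C(=O)c3ccc(F)c(F)c3)[nH]n2)cc(OC)c1OC`, is not yet measured. The change is 3,4-difluorophenyl in place of 4-methoxyphenyl on a carbonyl carbon. Within the data shown here, the one measured step that bears on it is the reverse exchange of a dihalogenated phenyl for the methoxyphenyl, which stayed within the scatter. So compound 3 is expected to land near the measured pair, with a number 6 percentage points lower from compound 2 to compound 3 (within the scatter) estimated to stay within the scatter. The estimate for compound 3 is 69%, ranging from 56% to 82%.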

Compound 3, a percentage reported as activity, at one concentration (the size of the read-out at that concentration, not a potency): 71%
The estimate for compound 3 lay 2 percentage points below the measured number, within the range that was stated.
By their numbers in this assay, from the lowest: compounds 1, 3 and 2 (each within the scatter of the next).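

On this carbonyl carbon, this assay now offers three aryl groups to compare, with a number 4 percentage points lower from compound 2 to compound 3 (within the scatter) and a number 4 percentage points higher from compound 1 to compound 3 (within the scatter) as the two new steps. Neither step separates the compounds, so 3,4-difluorophenyl, 3,4-dichlorophenyl and 4-methoxyphenyl cannot be told apart in this read-out. Nothing available explains this.

The compounds shown leave open whether a different kind of group on this carbonyl carbon, such as a simple amine or a carboxylic acid, would give a step beyond the scatter.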